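Cyano to methoxycarbonyl on a potassium channel opener core

The source may report more compounds than this note shows. Statements on the series, on what has been measured and on what is new or still open speak of the compounds shown alone.

Of the compounds shown here, two have so far been tested in a functional assay on cell membranes (Cavia porcellus) with sulfonylurea receptors; K-ATP channels (Homo sapiens) as the target, using a membrane potential dye; on this read-out higher numbers stand for an effect only at larger amounts of compound and lower numbers for an effect already at smaller amounts. Compound 1 `CCc1cc(C#N)ccc1Nc1c(N[C@H](C)C(C)(C)C)c(=O)c1=O` gives 251 nM in this assay. Compound 2 `CC1=C(C#N)C(c2ccc(F)c(Br)c2)C2=C(CCS2(=O)=O)N1` gives 27.5 nM in this assay, the lowest of the two numbers, and its gap to compound 1 lies beyond the usual scatter of repeated measurements. Compound 3 `COC(=O)C1=C(C)NC2=C(C1c1ccc(F)c(Br)c1)S(=O)(=O)CC2` has not yet been measured. It keeps the core of compound 2 and differs from it in one place: methoxycarbonyl in place of cyano on a double-bonded ring carbon. Among the measured compounds shown here, no step between measured compounds resembles this change, so the expectation rests on the change itself and on where compound 2 stands. The expected step is a 1.8-fold higher number from compound 2 to compound 3 (0.26 log units; within the scatter), a modest move towards a higher number that may still fall within the scatter. Compound 3 is therefore expected to give about 50 nM in this assay, with a likely range from 12 nM to 250 nM.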

Compound 3, half-maximal effective concentration: 53.7 nM
Compound 3: the middle estimate sits 1.1-fold (0.03 log units) below what was measured; low and high end bracket the measured number.
By their numbers in this assay, from the lowest: compounds 2 and 3 (each within the scatter of the next); then compound 1.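

In this assay, putting methoxycarbonyl in place of cyano on this double-bonded ring carbon gives a 2.0-fold higher number from compound 2 to compound 3 (0.29 log units; within the scatter) and so leaves the two compounds indistinguishable in this read-out. Among the compounds shown here, this is the first look at this position, and it shows that the number stays within the scatter even though the heavy atoms of the group rise from 2 to 4 and its hydrogen-bond acceptors from 1 to 2. No measurement at hand offers an explanation for this result.

As far as these compounds go, whether an ethyl ester, a carboxylic acid or an amide at this ring carbon would also stay within the scatter remains open. So does whether the same swap would read alike with a different group on the neighbouring ring atom that bears the group of 8 heavy atoms.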